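A Sugar Change Repeated on a Second Purine Core

This account rests on a few compounds, and the source may have more. Where it says the series, first, only, none or still open, it means among the compounds named here.

Three compounds have been characterised in a functional assay on M4Beu cells for cytotoxicity against M4Beu cell line (Homo sapiens), in the presence of a further agent that is not named here; a lower number here means that less compound is needed, a higher number that more compound is needed for the effect. Compound 1 `CC(=O)Nc1nc(OCc2ccccc2)c2ncn(C3O[C@H](O)[C@@H](O)[C@H]3O)c2n1` gives 200 uM in this assay. Compound 2 `CC(=O)Nc1nc(OCc2ccccc2)c2ncn(C3CC(O)C(O)O3)c2n1` shares its core but carries a smaller sugar and gives 165 uM in this assay; the change is 4,5-dihydroxyoxolan-2-yl in place of 3,4,5-trihydroxyoxolan-2-yl on an aromatic nitrogen and the measured step was a 1.2-fold lower number from compound 1 to compound 2 (0.08 log units; within the scatter). Compound 3 `Nc1nc(OCc2ccc(Br)cc2)c2ncn(C3O[C@H](O)[C@@H](O)[C@H]3O)c2n1` gives 277 uM in this assay. How compound 3 differs from compound 1 is not broken down here, and the two numbers lie within the usual scatter of each other, as do those of compound 3 and compound 2.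

Compound 4 `Nc1nc(OCc2ccc(Br)cc2)c2ncn(C3CC(O)C(O)O3)c2n1` has not yet been measured. It stands to compound 3 as compound 2 stands to compound 1: the change is 4,5-dihydroxyoxolan-2-yl in place of 3,4,5-trihydroxyoxolan-2-yl on an aromatic nitrogen, and the place around it reads the same in both pairs, so it is the same change made on a second core. Because the earlier step of a 1.2-fold lower number from compound 1 to compound 2 (0.08 log units; within the scatter) stayed within the scatter, the step expected from compound 3 to compound 4 is also small, and the estimate is a 1.2-fold lower number from compound 3 to compound 4 (0.08 log units; within the scatter) in this assay. That expectation rests only on compound 1 and compound 2 and on the value of compound 3, 277 uM; a single precedent gives little certainty. Compound 4 is therefore estimated at 230 uM in this assay, with a plausible range from 130 uM to 420 uM.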

Compound 4, concentration for half-maximal effect: 4 uM
Compound 4: the middle estimate sits 58-fold (1.76 log units) above what was measured; the whole stated range lies above it.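

On the second core the sugar change behaves very differently from the first: in this assay it gives a 69-fold lower number from compound 3 to compound 4 (1.84 log units; beyond the scatter), and the small step seen on the core of compound 1 did not carry over, as the two steps set side by side show: the same change on two cores in this assay, a 1.2-fold lower number (0.08 log units; within the scatter) from compound 1 to compound 2 and a 69-fold lower number (1.84 log units; beyond the scatter) from compound 3 to compound 4, 57-fold (1.76 log units) apart, beyond the scatter of two such steps For these two pairs, then, the outcome of putting 4,5-dihydroxyoxolan-2-yl in place of 3,4,5-trihydroxyoxolan-2-yl depends on the core that carries it, so the step on one core could not be transferred to the other. The pairs do not show which difference between the cores matters, since the core of compound 1 has an acetyl group on its amino group and an unsubstituted benzyl group, while the core of compound 3 has a free amino group and a bromine on the benzyl group, and they do not show how any third core would behave.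

On these data alone, it remains open whether the large step needs the free amino group, the bromine or both, and whether a chlorine or a methoxy group in place of the bromine, or a propionyl group on the amino group, would give a large step or a small one. Also open, as far as these compounds go, is whether compound 4 at 4 uM would keep this value without the further agent present in this assay.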